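The compounds below may be only part of what the source reports. "The series", "measured", "known", "first", "only" and "open" are said of these compounds alone.

Working notes on the series. Among the measured compounds shown here, in a functional assay on MCF7 cells (Homo sapiens) for cytotoxicity, read by MTT assay, with a stated time of 72 h, tested at 1 uM (on this read-out higher numbers stand for more inhibition of growth at the one concentration tested and lower numbers for less inhibition of growth), compound 1 `N/C(=N\NC(=S)N1CCOCC1)c1ccc(F)cn1` gives 12.4%, which is the lowest of the three numbers so far. Compound 2 `N/C(=N\NC(=S)N1CCOCC1)c1ccccn1` gives 14.7%, and the step of a number 2.3 percentage points higher from compound 1 to compound 2 (within the scatter) shows that swapping fluoro for hydrogen on the aromatic carbon leaves the read-out essentially unchanged. For the measured compounds named here, compound 3 `N/C(=N\NC(=S)N1CCN(c2ccccn2)CC1)c1ccccn1` gives 36%; compound 3 and compound 2 differ in the group on the thiocarbonyl carbon, and their two values lie well apart, so that position is the one where the numbers have moved so far.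

Compound 4 `N/C(=N\NC(=S)N1CCCC1)c1ccc(F)cn1` is the next case: pyrrolidin-1-yl in place of morpholin-4-yl on a thiocarbonyl carbon. Going by the values given here, no measured step covers this exact exchange, so nothing here settles its direction. Among the compounds with values here, the only change at the thiocarbonyl carbon seen so far, from compound 2 to compound 3, involved a larger ring-bearing group and went upward, whereas pyrrolidin-1-yl is smaller than morpholin-4-yl and loses the one hydrogen-bond acceptor. With compound 1 at the bottom of the range, little room exists for a downward move, while an upward move of the size seen between compound 2 and compound 3 cannot be ruled out. The expectation is a step of a number 3.6 percentage points higher from compound 1 to compound 4 (within the scatter) that most likely stays within the scatter, with the range skewed upward. Compound 4 is therefore estimated at 16%, between 2% and 36%.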

Compound 4, percent growth inhibition at one concentration: 51%
For compound 4 the middle estimate is 35 percentage points below the measured one; the measured number lies above the stated range.
By their numbers in this assay, from the lowest: compounds 1 and 2 (each within the scatter of the next); then compound 3; then compound 4.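

In this assay, pyrrolidin-1-yl in place of morpholin-4-yl on a thiocarbonyl carbon gives a number 38.6 percentage points higher from compound 1 to compound 4 (beyond the scatter), a far larger change than the exchange on the aromatic carbon, a number 2.3 percentage points higher from compound 1 to compound 2 (within the scatter). Until now, the only movement at the thiocarbonyl carbon came with a larger group, in compound 2 at 14.7% and compound 3 at 36%; the new result shows that a smaller group, a five-membered non-aromatic ring with 1 hetero atom replacing a six-membered one with 2 hetero atoms, can also raise the read-out, so among these compounds larger size at this position is not required for a higher number. Nothing available here explains why this exchange has so large an effect.

From the compounds shown here alone, it remains open whether pyrrolidin-1-yl gives a step of similar size when hydrogen rather than fluoro sits on the aromatic carbon. Going by these compounds, it is also open where piperidin-1-yl or an open-chain dimethylamino group on the thiocarbonyl carbon would fall, which would help separate the effect of ring size from that of the ring oxygen.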